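From Nitro to Fluoro: Compound 3 Awaits Measurement

A few compounds are considered here, and "the series" means these few. Any claim that something is new, unique, unknown or untested is made for them only; others in the source may bear on it.

Measured in a functional assay on MCF7 cells (Homo sapiens) for inhibition, read by MTT assay, with a stated time of 48 h; on this read-out lower numbers stand for stronger inhibition and higher numbers for weaker inhibition:
Compound 1 `Clc1ccc(CSc2nnc(-c3ccncc3)n2-c2ccccc2)cc1`: 13300 nM
Compound 2 `O=C(CSc1nnc(-c2ccncc2)n1-c1ccccc1)N/N=C/c1ccc([N+](=O)[O-])cc1`: 15300 nM

Within the data shown here, only two compounds carry numbers so far, and they sit close together. Compound 2 holds the higher of the two values, yet its distance to compound 1 lies within the usual scatter of this read-out, so nothing separates compound 2 from compound 1 on the numbers shown. Among the measured compounds shown here, no pair differing in a single place has been measured, so no step of known size exists to lean on.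

Compound 3 `O=C(CSc1nnc(-c2ccncc2)n1-c1ccccc1)N/N=C/c1ccc(F)cc1` is the next compound to be tested. It differs from compound 2 in one place: fluoro in place of nitro on an aromatic carbon. The two measured compounds give no guidance on what such an exchange on the terminal ring does in this assay. The author therefore expects no step beyond the scatter, with the estimated shift from compound 2 to compound 3 being a 1.1-fold lower number from compound 2 to compound 3 (0.04 log units; within the scatter) in either direction at most. For compound 3 in this assay the estimate is 14000 nM, within a range of 5000 nM to 40000 nM.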

Compound 3, half-maximal inhibitory concentration: 12300 nM
Beside the measured number, compound 3's estimate is 1.1-fold (0.06 log units) above it; measured number inside the range.
By their numbers in this assay, from the lowest: compounds 3, 1 and 2 (each within the scatter of the next).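

In this assay, among these compounds, the exchange of 4-nitrophenyl to 4-fluorophenyl supplies the first comparison that differs in one place, and it gives a 1.2-fold lower number from compound 2 to compound 3 (0.09 log units; within the scatter). At this position, on an aromatic carbon of a six-membered aromatic ring of carbon only and para to a large group, the read-out therefore does not separate fluoro from nitro, even though nitro has 3 heavy atoms and 2 hydrogen-bond acceptors while fluoro has 1 heavy atom and 0 hydrogen-bond acceptors. No other measurement accompanies this step, so nothing shown speaks to what lies behind the result.

Whether an amine or a carboxylic acid on the same aromatic carbon would give a step beyond the scatter remains open, since the two groups compared here are the only ones shown at this position. Among the compounds shown here, compound 1 differs from compound 2 and compound 3 in more than one place, so the part of the molecule that separates it from them also has no step of its own to read.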